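Substituent steps on the fused ring of compound 3

The source may hold more compounds than are shown below. What is called first, only, known or untested is meant among the compounds shown, and "the series" means these compounds.

Measured so far:
compound 1, `CC(C)(O)c1cncc(-n2ncc3ccccc32)c1`: 15 nM
compound 2, `Cc1ccc2c(cnn2-c2cncc(C(C)(C)O)c2)c1`: 97.9 nM
compound 3, `CC(C)(O)c1cncc(-n2ncc3cc(C(F)(F)F)ccc32)c1`: 507 nM

In an assay on cells for inhibition of cytochrome P450 11B2, mitochondrial (Homo sapiens), read by HTRF, with stated times of 1 h and 3 h (on this read-out higher numbers stand for weaker inhibition and lower numbers for stronger inhibition), compound 3 stands highest of the three numbers; the steps of a 5.2-fold higher number from compound 2 to compound 3 (0.71 log units; beyond the scatter) and a 34-fold higher number from compound 1 to compound 3 (1.53 log units; beyond the scatter) set its distance from the other two. Compound 4, `CC(C)(O)c1cncc(-n2ncc3cc(C#N)ccc32)c1`, differs from compound 3 by cyano in place of trifluoromethyl on an aromatic carbon. For the measured compounds named here, no measured step exchanges a trifluoromethyl for a cyano. The steps at that carbon are a 6.5-fold higher number from compound 1 to compound 2 (0.81 log units; beyond the scatter), a 34-fold higher number from compound 1 to compound 3 (1.53 log units; beyond the scatter) and a 5.2-fold higher number from compound 2 to compound 3 (0.71 log units; beyond the scatter), each raising the number as the group grows from hydrogen to methyl to trifluoromethyl. A cyano there is expected to give a modest downward step, a 2.5-fold lower number from compound 3 to compound 4 (0.40 log units; beyond the scatter), landing between the methyl and trifluoromethyl outcomes. The estimate for compound 4 in this assay is 200 nM, with a range of 60 nM to 700 nM.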

Compound 4, half-maximal inhibitory concentration: 1160 nM
The estimate for compound 4 lay 5.8-fold (0.76 log units) below the measured number; the measured number lies above the stated range.
By their numbers in this assay, from the lowest: compound 1; then compound 2; then compound 3; then compound 4.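

In this assay cyano gives a 2.3-fold higher number from compound 3 to compound 4 (0.36 log units; beyond the scatter) at this carbon, so the number does not follow heavy-atom count: cyano carries fewer heavy atoms than trifluoromethyl. Hydrogen stays lowest of the four groups, with a 77-fold higher number from compound 1 to compound 4 (1.89 log units; beyond the scatter) and, against methyl, a 12-fold higher number from compound 2 to compound 4 (1.07 log units; beyond the scatter) on the same carbon. Nothing at hand bears on why cyano stands above trifluoromethyl here. Still open, as far as these compounds go, is whether an amine, a methoxy or a carboxylic acid at this carbon would bring the number back towards that of compound 1.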